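This account rests on a few compounds, and the source may have more. Where it says the series, first, only, none or still open, it means among the compounds named here.

Measured compounds:
compound 1, `CC1CCC(C(=O)N2CC(c3nc(-c4cccc(Cl)c4)no3)C2)CC1`, 1500 nM in an assay on HEK293 cells for positive allosteric modulation of metabotropic glutamate receptor 5 (Homo sapiens), read by FLIPR; on this read-out lower numbers stand for an effect already at smaller amounts and higher numbers for an effect only at larger amounts of compound
compound 2, `O=C(C1CCC(F)(F)CC1)N1CC(c2nc(-c3cccc(Cl)c3)no2)C1`, 180 nM in this assay

Within this pair compound 2 holds the lower number; the step of an 8.3-fold lower number from compound 1 to compound 2 (0.92 log units; beyond the scatter) separates it from compound 1, the only other measured compound. Compound 3, `O=C(N1CCCCCC1)N1CC(c2nc(-c3cccc(Cl)c3)no2)C1`, has not yet been measured in this assay. It differs from compound 2 in that (azepan-1-yl in place of 4,4-difluorocyclohexyl on a carbonyl carbon). Within the data shown here, the single measured step, an 8.3-fold lower number from compound 1 to compound 2 (0.92 log units; beyond the scatter), concerns a change on the cyclohexyl ring itself, one saturated carbon ring replacing another with different substitution, and does not speak to the exchange of a carbon ring for a nitrogen-containing ring that turns the amide carbonyl into a urea carbonyl. Among the measured compounds shown here, no measured step therefore bears directly on the change from compound 2 to compound 3, and the expectation rests on the position of compound 2 alone. Compound 3 is expected to give roughly 400 nM in this assay, the estimated step of a 2.2-fold higher number from compound 2 to compound 3 (0.35 log units; beyond the scatter) pointing to a somewhat higher number, with the range 100 nM to 1600 nM wide enough to allow no change beyond the scatter.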

Compound 3, half-maximal effective concentration: 47 nM
Compound 3: the middle estimate sits 8.5-fold (0.93 log units) above what was measured; the measured number lies below the stated range.
By their numbers in this assay, from the lowest: compound 3; then compound 2; then compound 1.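

At this place on a carbonyl carbon, whose other neighbour is an amide-type nitrogen in a ring, the earlier compounds had shown only carbon rings, and a carbon-only ring now proves not to be required: in this assay azepan-1-yl in place of 4,4-difluorocyclohexyl gives a still lower number (a 3.8-fold lower number from compound 2 to compound 3 (0.58 log units; beyond the scatter)) without any fluorine in the group. Measured against 4-methylcyclohexyl, the same group gives the largest step among these compounds (a 32-fold lower number from compound 1 to compound 3 (1.50 log units; beyond the scatter)), and compound 3 now holds the lowest number of the three, with its steps to both others beyond the scatter. Nothing available explains either step.

The change alters both the ring size and the atom that joins the ring to the carbonyl carbon, so the compounds shown leave open which of the two goes with the lower number; piperidin-1-yl and cycloheptyl at this place would separate them. Also open, going by these compounds, is whether 4,4-difluoroazepan-1-yl, which would bring the two fluorines of compound 2 onto the ring of compound 3, would lower the number further.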